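Aryl replacement on the weakest member of the series

This account rests on a few compounds, and the source may have more. Where it says the series, first, only, none or still open, it means among the compounds named here.

Within the data shown here, compound 3 `CC(C)C[C@H](N)CN(C(=O)[C@@H]1C[C@H]1c1ccccc1)c1ccc(-c2ccsc2)cc1` stands highest of the three numbers so far in a functional assay for agonist activity at G protein-coupled receptor 88 (Homo sapiens), read by HTRF and cAMP accumulation (a higher number here means that more compound is needed for the effect, a lower number that less compound is needed), giving 1200 nM. Among the measured compounds shown here, compound 1 `CC(C)(C)[C@H](N)CN(C(=O)[C@@H]1C[C@H]1c1ccccc1)c1ccc(-c2ccccc2)cc1` gives 11 nM and compound 2 `CC(C)C[C@H](N)CCN(C(=O)[C@@H]1C[C@H]1c1ccccc1)c1ccc(-c2ccccc2)cc1` gives 3 nM; the one measured step, a 3.7-fold lower number from compound 1 to compound 2 (0.56 log units; beyond the scatter), concerns the saturated chain and not the aromatic terminus. Compound 4 `CC(C)C[C@H](N)CN(C(=O)[C@@H]1C[C@H]1c1ccccc1)c1ccc(-c2cccc(F)c2)cc1` differs from compound 3 by 3-fluorophenyl in place of thiophen-3-yl on an aromatic carbon. For the measured compounds named here, no measured step touches this position, so the expectation rests on compounds 1 and 2 carrying an unsubstituted phenyl there with low values, against the thiophen-3-yl of compound 3. A large drop is therefore expected, a 30-fold lower number from compound 3 to compound 4 (1.48 log units; beyond the scatter), though the two-site difference from compound 3 to compound 1 leaves the size uncertain. For compound 4 the estimate is 40 nM, within 6 nM to 300 nM.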

Compound 4, half-maximal effective concentration: 2100 nM
Compound 4: the middle estimate sits 53-fold (1.72 log units) below what was measured; the whole stated range lies below it.
By their numbers in this assay, from the lowest: compound 2; then compound 1; then compounds 3 and 4 (each within the scatter of the next).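

In this assay, the change to 3-fluorophenyl in place of thiophen-3-yl on an aromatic carbon gives a 1.8-fold higher number from compound 3 to compound 4 (0.24 log units; within the scatter). With the rest of the structure held constant, this position therefore does not separate the five-membered sulfur ring from the fluorinated six-membered ring, and ring size alone does not shift the reading between these two compounds. Nothing measured here offers an explanation for this result.

Still open, going by these compounds, is how an unsubstituted phenyl would read on the chain of compounds 3 and 4. On these data alone, the readings of 2-fluorophenyl and pyridin-3-yl at this position also remain open.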